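Aryl swap on a thiourea-linked side chain: compound 4

The source may hold more compounds than are shown below. What is called first, only, known or untested is meant among the compounds shown, and "the series" means these compounds.

Measured compounds:
Compound 1 `CC1=CC[C@@H]([C@@](C)(O)CCCC(C)(C)NC(=S)NN)CC1` gives 26800 nM in a functional assay on PCO3 cells (Homo sapiens) for cytotoxicity, read by sulforhodamine B assay; a higher number here means a weaker inhibitor of growth, a lower number a stronger inhibitor of growth.
Compound 2 `CC1=CC[C@@H]([C@@](C)(O)CCCC(C)(C)NC(=S)N/N=C\c2ccc(N(C)C)cc2)CC1` gives 13700 nM in this assay.
Compound 3 `CC1=CC[C@@H]([C@@](C)(O)CCCC(C)(C)NC(=S)N/N=C\c2ccccc2[N+](=O)[O-])CC1` gives 39900 nM in this assay.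

Compound 3 has the highest of the three numbers, although compound 1 lies within the scatter of it; only compound 2 is clearly apart, by a 2.9-fold higher number from compound 2 to compound 3 (0.46 log units; beyond the scatter), a modest step. Compound 4 `CC1=CC[C@@H]([C@@](C)(O)CCCC(C)(C)NC(=S)N/N=C\c2cccc(Cl)c2)CC1` differs from compound 3 in one place: 3-chlorophenyl in place of 2-nitrophenyl on a carbon with a double bond to nitrogen. Among the measured compounds shown here, the one measured step that bears on this is a 2.9-fold higher number from compound 2 to compound 3 (0.46 log units; beyond the scatter), where exchanging the same aryl group shifted the number modestly. A shift of similar size is therefore expected here, most likely downward, though no change beyond the scatter would also be unsurprising. The expected step for compound 4 is a 1.6-fold lower number from compound 3 to compound 4 (0.20 log units; within the scatter). Compound 4 is therefore estimated at 25000 nM, with a range from 10000 nM to 60000 nM.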

Compound 4, concentration for 50% growth inhibition: 11300 nM
The estimate for compound 4 lay 2.2-fold (0.34 log units) above the measured number; the measured number falls inside the stated range.
By their numbers in this assay, from the lowest: compounds 4, 2, 1 and 3 (each within the scatter of the next, the first and the last beyond it).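

Replacing 2-nitrophenyl with 3-chlorophenyl gives a 3.5-fold lower number from compound 3 to compound 4 (0.55 log units; beyond the scatter) and moves the number beyond the scatter, while replacing 4-(dimethylamino)phenyl with it gives only a 1.2-fold lower number from compound 2 to compound 4 (0.08 log units; within the scatter) and leaves two very different aryl groups level, with 2-nitrophenyl apart from both. Against the unsubstituted nitrogen end of compound 1, the 3-chlorophenyl-bearing side chain gives a 2.4-fold lower number from compound 1 to compound 4 (0.38 log units; beyond the scatter) as a second step beyond the scatter. Nothing measured here explains these differences.

From the compounds shown here alone, a plain phenyl and a 3-nitrophenyl remain open, and they could show whether the substituent itself or its ring position matters more.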